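Methyl in place of cyclopropyl on the shared core

A few compounds are considered here, and "the series" means these few. Any claim that something is new, unique, unknown or untested is made for them only; others in the source may bear on it.

Compound 2 `CC(C)c1nc2c(c(C3CC3)nn2C)c(-c2ccc(F)cc2)c1/C=C/[C@@H](O)C[C@@H](O)CC(=O)O` carries a cyclopropyl group on an aromatic carbon of the shared core, where compound 1 `CC(C)c1nc2c(c(-c3ccccc3)nn2C)c(-c2ccc(F)cc2)c1/C=C/[C@@H](O)C[C@@H](O)CC(=O)O` carries a phenyl group. In an in vivo functional assay on the whole organism for inhibition of 3-hydroxy-3-methylglutaryl-coenzyme A reductase (Rattus norvegicus), at a dose of 2 mg/kg by the oral route (a higher number here means a stronger effect of the compound at the dose given, a lower number a weaker effect), compound 1 gives 71.1% and compound 2 gives 71.3%. Compound 2 has the higher of the two numbers, but the gap, a number 0.2 percentage points higher from compound 1 to compound 2 (within the scatter), is within the scatter, so the two compounds cannot be told apart on these data. Compound 3 `Cc1nn(C)c2nc(C(C)C)c(/C=C/[C@@H](O)C[C@@H](O)CC(=O)O)c(-c3ccc(F)cc3)c12` is not yet measured; it differs from compound 2 in one place: methyl in place of cyclopropyl on an aromatic carbon. For the measured compounds named here, the only measured step that bears on this change is the exchange of the group on that aromatic carbon from compound 1 to compound 2, and that step was flat. The expectation is therefore no step beyond the scatter in this assay, with a number 2.3 percentage points lower from compound 2 to compound 3 (within the scatter) as the estimated change. For compound 3 the expected value in this assay is 69%, within a range from 55% to 82%.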

Compound 3, a percentage reported as inhibition, in the whole organism at one dose (the size of the read-out at that dose, not a potency): 48.1%
The estimate for compound 3 lay 20.9 percentage points above the measured number; measured number outside the range, below it.
By their numbers in this assay, from the lowest: compound 3; then compounds 1 and 2 (each within the scatter of the next).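

In this assay this position on the five-membered aromatic ring proves sensitive to the group it carries, a fact the flat exchange of phenyl for cyclopropyl could not reveal: the change to methyl gives a number 23.2 percentage points lower from compound 2 to compound 3 (beyond the scatter) and, from the phenyl compound, a number 23 percentage points lower from compound 1 to compound 3 (beyond the scatter). Phenyl and cyclopropyl remain within the scatter of each other, and each stands clear of methyl, the only group of the three without a ring. No measured evidence is available to explain this loss.

The compounds shown leave open whether the ring itself matters or simply the number of heavy atoms, which an ethyl or isopropyl group at this position would help to separate. They also leave open how a group carrying an amine or a hydroxymethyl group would fare here.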